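The source may report more compounds than this note shows. Statements on the series, on what has been measured and on what is new or still open speak of the compounds shown alone.

Measured compounds, cytotoxicity:
compound 1 `Clc1ccc(C(Oc2ccc3cc(Br)ccc3c2)c2cnc(NCC3CCCCC3)s2)cc1`: "not toxic" (no number reported)
compound 2 `COc1ccc(C(=O)Nc2ncc(C(Oc3ccc4cc(Br)ccc4c3)c3ccc(Cl)cc3)s2)cc1`: > 50000 nM
compound 3 `O=C(Nc1ncc(C(Oc2ccc3cc(Br)ccc3c2)c2ccc(Cl)cc2)s1)c1ccc(Cl)nc1`: "not toxic" (no number reported)

In an ADME assay on HepG2 2.2.15 cells (Homo sapiens) for cytotoxicity (a higher number here means that more compound is tolerated, a lower number that less compound is tolerated), compound 3 gives "not toxic" (no number reported), so no single number stands for it. In this assay compound 2 gives > 50000 nM, which is a limit of the assay rather than a number. Compound 1 likewise gives "not toxic" (no number reported) in this assay. Among the compounds with values here, one of the three values sits at the limit of > 50000 nM in this assay, at which 1 of the 3 values shown sits; the other two carry no number at all, so no step between measured compounds can be given.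

The next compound, compound 4 `O=S(=O)(Nc1ncc(C(Oc2ccc3cc(Br)ccc3c2)c2ccc(Cl)cc2)s1)c1ccccc1`, differs from compound 3 by phenylsulfonyl in place of (6-chloropyridin-3-yl)carbonyl on a nitrogen on an aromatic ring. With every measured value either at the upper limit or unquantified, no direction beyond the scatter is expected in this assay; compound 4 is most likely to return a limit again. Compound 4 is estimated at 50000 nM in this assay, within 20000 nM to 100000 nM.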

Compound 4, half-maximal cytotoxic concentration: > 50000 nM
Compound 4 ended at the assay's limit (the forecaster's own chance of this, stated with the estimate: 70%); the middle value sits exactly at the limit.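

No step can be read from compound 2 to compound 4, because both compounds stand at a limit rather than a number: the limit of > 50000 nM in this assay, at which 2 of the 4 values shown sit. The compounds shown leave open whether any group on this nitrogen changes the result in this assay at all.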